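The source may report more compounds than this note shows. Statements on the series, on what has been measured and on what is new or still open speak of the compounds shown alone.

Compound 2 `CNC(=O)c1cnc(N2CCN(C3CCN(C(F)(F)F)CC3)[C@@H](C)C2)c(Cl)c1` is the stronger of the two measured compounds in a functional assay for antagonist activity at C-X-C chemokine receptor type 3 (Homo sapiens) (on this read-out lower numbers stand for stronger inhibition and higher numbers for weaker inhibition), where compound 2 gives 63 nM. For the measured compounds named here, the other measured compound, compound 1 `CNC(=O)c1cnc(N2CCN(C3CCN(Cc4cccs4)CC3)[C@@H](C)C2)c(Cl)c1`, gives 1980 nM in this assay, and the single recorded step, a 31-fold lower number from compound 1 to compound 2 (1.50 log units; beyond the scatter), separates the two. Compound 3 `CNC(=O)c1cnc(N2CCN(C3CCN(Cc4ccc(Cl)cc4Cl)CC3)[C@@H](C)C2)c(Cl)c1` has not yet been measured in this assay. It differs from compound 2 by 2,4-dichlorobenzyl in place of trifluoromethyl on an amine nitrogen in a ring. Going by the values given here, only one measured step bears on this change, and it runs the opposite way: compound 1 carries a (thiophen-2-yl)methyl on that same amine nitrogen in a ring, and a 31-fold lower number from compound 1 to compound 2 (1.50 log units; beyond the scatter) shows how far the number fell when trifluoromethyl took its place. Compound 3 once more puts a ring-bearing group on that nitrogen, so a rise of comparable size is expected, a 24-fold higher number from compound 2 to compound 3 (1.38 log units; beyond the scatter). Compound 3 is therefore estimated to give 1500 nM in this assay, within a range from 300 nM to 8000 nM.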

Compound 3, half-maximal inhibitory concentration: 17 nM
For compound 3 the middle estimate is 88-fold (1.95 log units) above the measured one; measured number outside the range, below it.
By their numbers in this assay, from the lowest: compound 3; then compound 2; then compound 1.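

A ring-bearing group on this amine nitrogen does not by itself raise the number in this assay: 2,4-dichlorobenzyl in place of trifluoromethyl gives a 3.7-fold lower number from compound 2 to compound 3 (0.57 log units; beyond the scatter) and so takes the lowest place of the three. The identity of the ring on the saturated chain carbon counts for much more than its presence, since 2,4-dichlorophenyl in place of thiophen-2-yl gives a 120-fold lower number from compound 1 to compound 3 (2.07 log units; beyond the scatter) on an otherwise unchanged structure. No measurement given here accounts for either step.

The compounds shown leave open how an unsubstituted benzyl or a 4-chlorobenzyl would read on this nitrogen, so the share of each chlorine in these steps remains unknown. As far as these compounds go, it is equally open whether a pyridin-2-ylmethyl would fall nearer to compound 1 or to compound 3.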